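Replacing Trifluoromethyl with 4-Methylpiperazin-1-yl: Efficacy Outlook

This account rests on a few compounds, and the source may have more. Where it says the series, first, only, none or still open, it means among the compounds named here.

Measured so far:
Compound 1, `CC(C)[C@H](C(=O)NC(C)(C)C)c1ccc(Cl)cc1`, in a functional assay on CHO cells for agonist activity at Free fatty acid receptor 2 (Homo sapiens), read by cAMP accumulation (a higher number here means a larger maximal response, a lower number a smaller maximal response), gives < 30%, which is a limit of the assay.
Compound 2, `CC(C)[C@H](C(=O)Nc1ncc(C(F)(F)F)s1)c1ccc(Cl)cc1`, in this assay gives 95%.
Compound 3, `CC(C)(C)[C@H](C(=O)Nc1ncc(C(F)(F)F)s1)c1ccc(Cl)cc1`, in this assay gives 95%.

Compound 3 stands level with compound 2; the step of no change at the digits printed from compound 2 to compound 3 (within the scatter) lies within the scatter. Compound 1 sits at a limit of < 30% in this assay, at which 1 of the 3 values shown sits, and differs from compound 2 in the whole amide substituent, so only the two values themselves can be compared.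

Compound 4, `CN1CCN(c2cnc(NC(=O)[C@H](c3ccc(Cl)cc3)C(C)(C)C)s2)CC1`, differs from compound 3 in one place: 4-methylpiperazin-1-yl in place of trifluoromethyl on an aromatic carbon. Going by the values given here, no measured step touches this position; the single measured step, no change at the digits printed from compound 2 to compound 3 (within the scatter), concerns the saturated chain and was flat. Compound 1 and compound 2 show that the group on the amide nitrogen can shift the read-out from a limit to a large response, so a sizeable movement in this assay cannot be ruled out. With compound 3 at 95%, the room above is small, so any change is expected to run downward. Compound 4 is therefore expected to give 80%, between 40% and 105%, an expected step of a number 15 percentage points lower from compound 3 to compound 4 (beyond the scatter).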

Compound 4, largest response reached (reported as efficacy), in percent of the reference or control that the assay uses: 113%
For compound 4 the middle estimate is 33 percentage points below the measured one; measured number above the stated range.
By their numbers in this assay, from the lowest: compounds 2 and 3 (each within the scatter of the next); then compound 4. At a limit, below all of these: compound 1.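

Going by these compounds alone, the position next to the ring sulfur, which no earlier step had touched, proves responsive in this assay: exchanging trifluoromethyl for 4-methylpiperazin-1-yl gives a number 18 percentage points higher from compound 3 to compound 4 (beyond the scatter). The site therefore tolerates a six-membered non-aromatic ring with 2 hetero atoms in place of a group with no ring, and the response of compound 3, at 95%, was not the top of the read-out. Nothing measured here accounts for the gain.

With a single replacement shown at this position, it remains open whether the gain follows from the ring, its nitrogens or the methyl on it; a morpholine, an unsubstituted piperazine or an open-chain amine would separate these. As far as these compounds go, it is also open whether the same exchange would produce a similar step on compound 2.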